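The source may hold more compounds than are shown below. What is called first, only, known or untested is meant among the compounds shown, and "the series" means these compounds.

Measured compounds:
compound 1 `COc1cc(/C=C/C(=O)/C=C/c2cccc3ccccc23)ccc1OCc1cn(CCCOc2cc(=O)oc3ccccc23)nn1`: 64%
compound 2 `COc1cc(/C=C/C(=O)/C=C/c2cccc3ccccc23)ccc1OCc1cn(CCCCCOc2cc(=O)oc3ccccc23)nn1`: 40%

In a functional assay on COLO 205 cells (Homo sapiens) for inhibition, read by sulforhodamine B assay, with a stated time of 48 h, tested at 50 uM (on this read-out higher numbers stand for more inhibition of growth at the one concentration tested and lower numbers for less inhibition of growth), compound 1 stands highest of the two measured compounds at 64%, and the gap down to compound 2 at 40% lies beyond the usual scatter. The next compound to be tested is compound 3 `COc1ccccc1/C=C/C(=O)/C=C/c1ccc(OCc2cn(CCCOc3cc(=O)oc4ccccc34)nn2)c(OC)c1`. It keeps the core of compound 1 but has 2-methoxyphenyl in place of naphthalen-1-yl on a double-bonded chain carbon bound to a double-bonded chain carbon. Within the data shown here, no measured pair shows a change of this kind, so the data offer no direct guide. A modest loss in this assay is expected, and it may not clear the scatter. The expected step is a number 9 percentage points lower from compound 1 to compound 3 (within the scatter). For compound 3 the estimated value is 55%, with an expected range from 35% to 75%.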

Compound 3, percent growth inhibition at one concentration: 57%
Estimate against measurement, compound 3: 2 percentage points below; low and high end bracket the measured number.
By their numbers in this assay, from the lowest: compound 2; then compounds 3 and 1 (each within the scatter of the next).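

In this assay the first change shown on a double-bonded chain carbon bound to a double-bonded chain carbon, 2-methoxyphenyl in place of naphthalen-1-yl, gives a number 7 percentage points lower from compound 1 to compound 3 (within the scatter), so this pair shows no measurable loss. Going from two six-membered aromatic rings of carbon only to one, with one hydrogen-bond acceptor entering, therefore leaves the growth inhibition of this pair unchanged within the usual scatter. Nothing measured here accounts for this result.

As far as these compounds go, it remains open whether the methoxy group of 2-methoxyphenyl contributes at all, or whether a plain phenyl, a pyridinyl ring or an aminophenyl group at this place would give a similar number. Also open, from the compounds shown here alone, is whether the same replacement would hold on the longer chain of compound 2.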